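Swapping a Cyclopropylmethoxy Tail for a Methoxyethoxy Tail

The source may hold more compounds than are shown below. What is called first, only, known or untested is meant among the compounds shown, and "the series" means these compounds.

Compound 2 `Cc1cc(OCC2CC2)cc(C)c1-c1cccc(COc2ccc(S(=O)(=O)CC(=O)O)cc2)c1` gives 79.4 nM in a functional assay on CHO cells for agonist activity at Free fatty acid receptor 1 (Homo sapiens), read by FLIPR and calcium flux (on this read-out higher numbers stand for an effect only at larger amounts of compound and lower numbers for an effect already at smaller amounts), the higher of the two numbers in hand; compound 1 `Cc1cccc(C)c1-c1cccc(COc2ccc(S(=O)(=O)CC(=O)O)cc2)c1` gives 66.1 nM, and the step of a 1.2-fold higher number from compound 1 to compound 2 (0.08 log units; within the scatter) shows that adding the ether tail barely mattered. Compound 3 `COCCOc1cc(C)c(-c2cccc(COc3ccc(S(=O)(=O)CC(=O)O)cc3)c2)c(C)c1` changes that tail: methoxymethyl in place of cyclopropyl on a saturated chain carbon bound to an oxygen on an aromatic ring. Among the measured compounds shown here, no measured step touches the far end of this chain, so the only guide is that the tail's presence left the read-out unchanged. The estimate for compound 3 is therefore no move beyond the scatter, a 1.1-fold higher number from compound 2 to compound 3 (0.05 log units; within the scatter), giving 90 nM with a range of 35 nM to 230 nM.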

Compound 3, half-maximal effective concentration in the Free fatty acid receptor 1 assay: 126 nM
For compound 3 the middle estimate is 1.4-fold (0.15 log units) below the measured one, within the range that was stated.
By their numbers in the Free fatty acid receptor 1 assay, from the lowest: compounds 1, 2 and 3 (each within the scatter of the next).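

In the Free fatty acid receptor 1 assay compound 3 gives 126 nM, and methoxymethyl in place of cyclopropyl gives a 1.6-fold higher number from compound 2 to compound 3 (0.20 log units; within the scatter) and so the ring can give way to an open chain carrying an oxygen without a clear shift in the read-out. Set against the unsubstituted position, 2-methoxyethoxy in place of hydrogen gives a 1.9-fold higher number from compound 1 to compound 3 (0.28 log units; within the scatter) and so neither ether tail has moved the number beyond the scatter. Nothing available explains these numbers.

As far as these compounds go, whether a tail ending in an amine or a carboxylic acid would shift the read-out stays open. In a physicochemical assay for lipophilicity, using the shake flask method, in phosphate buffer, measured as octanol-water partition, with a stated time of 24 h, at pH 7.4, tested at 100 uM (on this read-out lower numbers stand for lower lipophilicity and higher numbers for higher lipophilicity), compound 2 gives 3.46 and compound 3 is recorded as "not determined" (no result reported), so compound 3 has no number to set against it.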